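This account rests on a few compounds, and the source may have more. Where it says the series, first, only, none or still open, it means among the compounds named here.

Two measured compounds share one core and differ only in the group on an aromatic carbon of the five-membered ring with three nitrogens. Compound 1, `C[C@H](NC(=O)c1c(C(F)(F)F)nnn1Cc1ccc(C(F)(F)F)cc1)c1ccc(C(=O)O)cc1`, carries a trifluoromethyl there; in a functional assay on CHO cells for antagonist activity at prostaglandin E2 receptor EP4 subtype (Homo sapiens), read by calcium flux, with a stated time of 15 min (a lower number here means a stronger inhibitor, a higher number a weaker inhibitor), compound 1 gives 225 nM. Compound 2, `C[C@H](NC(=O)c1c(C2CCCC2)nnn1Cc1ccc(C(F)(F)F)cc1)c1ccc(C(=O)O)cc1`, carries a cyclopentyl instead, and in this assay compound 2 gives 65.1 nM. Among the compounds with values here, that single exchange produced a 3.5-fold lower number from compound 1 to compound 2 (0.54 log units; beyond the scatter), so compound 2 stands lowest of the two numbers, with compound 1 as its only neighbour at a higher number beyond the scatter.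

Compound 3, `C[C@H](NC(=O)c1c(-c2ccc(F)cc2)nnn1Cc1ccc(C(F)(F)F)cc1)c1ccc(C(=O)O)cc1`, changes the same place once more: 4-fluorophenyl in place of cyclopentyl on an aromatic carbon. Within the data shown here, only the step from compound 1 to compound 2 bears on this, and it shows that a carbon ring at this position gave a lower number than trifluoromethyl. A six-membered aromatic ring is a different kind of ring, so the earlier step is a guide rather than a measure. The expectation is a step of a 1.3-fold lower number from compound 2 to compound 3 (0.11 log units; within the scatter) in this assay, no larger than the scatter or a little lower. Compound 3 is therefore estimated at 50 nM, within a range of 15 nM to 170 nM.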

Compound 3, half-maximal inhibitory concentration: 57.9 nM
The estimate for compound 3 lay 1.2-fold (0.06 log units) below the measured number; low and high end bracket the measured number.
By their numbers in this assay, from the lowest: compounds 3 and 2 (each within the scatter of the next); then compound 1.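

Replacing cyclopentyl with 4-fluorophenyl gives a 1.1-fold lower number from compound 2 to compound 3 (0.05 log units; within the scatter) in this assay, so this position accepts either a non-aromatic five-membered carbon ring or an aromatic six-membered carbon ring with no reading between them beyond the usual scatter. The earlier compounds shown here showed only that cyclopentyl gave a lower number than trifluoromethyl; the exchange of trifluoromethyl for 4-fluorophenyl gives a 3.9-fold lower number from compound 1 to compound 3 (0.59 log units; beyond the scatter), so the advantage over trifluoromethyl is not limited to cyclopentyl but also appears with a ring of a different size and aromatic character. No measurement shown here offers a reason why these two rings read alike or why both give lower numbers than trifluoromethyl.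

The compounds shown do not separate the contribution of the aromatic ring from that of its fluorine, since plain phenyl is not among them. Also open, on these data alone, is how this position would respond to a group of another kind, such as an amine, a carboxylic acid or a longer chain, and whether any of these would keep the number close to those of the two ring compounds.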